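Working notes on one mouse series and one untested addition

The source may hold more compounds than are shown below. What is called first, only, known or untested is meant among the compounds shown, and "the series" means these compounds.

Measured so far:
Compound 1 `O=C(N/N=C/c1ccc(Cl)cc1Cl)Nc1cccc2ccccc12` gives 300 mg/kg in a functional assay on the whole organism (strain Swiss albino) with Mus musculus as the target, with a stated time of 0.5 h; a lower number here means that less compound is needed, a higher number that more compound is needed for the effect.
Compound 2 `O=C(N/N=C/c1ccccc1[N+](=O)[O-])Nc1cccc2ccccc12` gives 300 mg/kg in this assay.
Compound 3 `C/C(=N\NC(=O)Nc1cccc2ccccc12)c1ccc(C)cc1` gives 300 mg/kg in this assay.

Compound 1 stands level with compounds 2 and 3 at the digits reported; its nearest neighbour is compound 2 and its furthest is compound 3, and neither gap goes beyond the usual scatter. Within the data shown here, no pair of measured compounds differs in a single place, so no measured step size is available. Compound 4 `O=C(N/N=C/c1ccc(F)cc1)Nc1cccc2ccccc12` is the untested member; it differs from compound 1 in that (4-fluorophenyl in place of 2,4-dichlorophenyl on a carbon with a double bond to nitrogen). The measured values give no sign that the group on the carbon with a double bond to nitrogen moves the dose: compounds 1, 2 and 3 carry different groups there and agree. For compound 4 the expected step of no change at the digits printed from compound 1 to compound 4 (within the scatter) is none beyond the scatter. Compound 4 is estimated at 300 mg/kg in this assay, with a range of 100 mg/kg to 1000 mg/kg.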

Compound 4, minimum effective dose: 300 mg/kg
Estimate against measurement, compound 4: no gap at the digits printed; low and high end bracket the measured number.
By their numbers in this assay, from the lowest: compounds 1, 2, 3 and 4 (each within the scatter of the next).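

Among these compounds, the first single-place step at this position, 4-fluorophenyl in place of 2,4-dichlorophenyl on a carbon with a double bond to nitrogen, gives no change at the digits printed from compound 1 to compound 4 (within the scatter) in this assay. The earlier agreement came only from compounds differing in more than one place, whereas this pair isolates one change of aryl group. No available evidence explains this result.

Going by these compounds, whether a carboxylic acid or an amine at this place would shift the dose remains open. On these data alone, the effect of changes to the shared core is also open.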